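Chain shortening toward compound 3 in the piperazine amide series

The compounds below may be only part of what the source reports. "The series", "measured", "known", "first", "only" and "open" are said of these compounds alone.

Measured so far:
compound 1, `COc1cccc(N2CCN(C(=O)C(C)N3C(=O)CCC3=O)CC2)c1`: 50%
compound 2, `CCC(C(=O)N1CCN(c2ccc(Cl)cc2)CC1)N1C(=O)CCC1=O`: 0%

In a functional assay on the whole organism (strain Swiss) with Mus musculus as the target, in the maximal electroshock model, with a stated time of 0.5 h, at a dose of 300 mg/kg by the intraperitoneal route (a lower number here means a weaker effect, a higher number a stronger effect of the compound at the dose given), compound 1 gives 50%, and compound 2 gives 0%. Compound 2 stands lowest of the two numbers; the gap to compound 1 lies beyond the scatter. Among the compounds with values here, the two compounds differ in more than one place, so no single step between them can be read.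

Compound 3, `CC(C(=O)N1CCN(c2ccc(Cl)cc2)CC1)N1C(=O)CCC1=O`, is not yet measured. It differs from compound 2 by one change: hydrogen in place of methyl on a saturated chain carbon, two bonds along the chain from an amide-type nitrogen in a ring and a carbonyl carbon. Compound 3 thus carries the same chain as compound 1 while keeping the rest of compound 2.

Expectation for this assay: compound 2 sits at the floor of the read-out, so a downward step is not possible, and the shared chain with compound 1 suggests an upward step for compound 3 of a number 30 percentage points higher from compound 2 to compound 3 (beyond the scatter) is expected, though the change in the aryl part of compound 2 against compound 1 is not separately known. Compound 3 is estimated at 30%, within 0% to 65%.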

Compound 3, a percentage reported as activity, at one dose (the size of the read-out at that dose, not a potency): 100%
For compound 3 the middle estimate is 70 percentage points below the measured one, outside the stated range (above it).
By their numbers in this assay, from the lowest: compound 2; then compound 1; then compound 3.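

In this assay, ethyl to methyl on a saturated chain carbon, two bonds along the chain from an amide-type nitrogen in a ring and a carbonyl carbon, gives a number 100 percentage points higher from compound 2 to compound 3 (beyond the scatter). With 4-chlorophenyl held constant, this single chain position therefore spans the full range of values seen in these compounds, a dependence that the earlier pair could not reveal. With the methyl-bearing chain held constant, 4-chlorophenyl in place of 3-methoxyphenyl on an amine nitrogen in a ring gives a number 50 percentage points higher from compound 1 to compound 3 (beyond the scatter), so the aryl group also matters, and no measurement here bears on the origin of either step.

The compounds shown leave open whether ethyl to methyl has a similar effect with 3-methoxyphenyl on the amine nitrogen, and how the read-out in this assay responds to a longer chain such as propyl at the same carbon. On these data alone, compound 3 gives 100% at one dose, which is not a potency, so its margin at lower doses also remains open.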